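Triazole-linked dithiocarbamates: a benzyl change on the ring nitrogen

The compounds below may be only part of what the source reports. "The series", "measured", "known", "first", "only" and "open" are said of these compounds alone.

Measured compounds:
compound 1 `CC(C)(C)OC(=O)N1CCN(C(=S)SCc2cn(Cc3cc(=O)oc4cc(O)ccc34)nn2)CC1` gives 4960 nM
compound 2 `Cc1ccc(-n2cc(CSC(=S)N3CCN(C(=O)OC(C)(C)C)CC3)nn2)cc1` gives 48300 nM

In a functional assay on MGC-803 cells (Homo sapiens) for inhibition, read by MTT assay, with a stated time of 72 h (on this read-out lower numbers stand for stronger inhibition and higher numbers for weaker inhibition), compound 2 stands at the highest of the two numbers. Its nearest neighbour is compound 1, whose number in this assay is lower by a gap that lies beyond the scatter. Compound 3 `CC(C)(C)OC(=O)N1CCN(C(=S)SCc2cn(Cc3ccccc3Cl)nn2)CC1` has not yet been measured. It differs from compound 2 in one place: 2-chlorobenzyl in place of 4-methylphenyl on an aromatic nitrogen. Compound 2 and compound 3 share the rest of the core. For the measured compounds named here, only two values are known and they do not isolate this change, so the step from compound 2 to compound 3 cannot be read from a measured pair. Since compound 1, which also carries a benzyl-type group on that ring nitrogen, gives 4960 nM, compound 3 is expected to give a lower number than compound 2, by a moderate step of a 3.2-fold lower number from compound 2 to compound 3 (0.51 log units; beyond the scatter). Compound 3 is estimated at 15000 nM, within 4000 nM to 50000 nM.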

Compound 3, half-maximal inhibitory concentration: 490 nM
The estimate for compound 3 lay 31-fold (1.49 log units) above the measured number; measured number below the stated range.
By their numbers in this assay, from the lowest: compound 3; then compound 1; then compound 2.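

The pair shows that the aromatic nitrogen of the five-membered ring is a position where the read-out in this assay can move strongly: 2-chlorobenzyl in place of 4-methylphenyl gives a 99-fold lower number from compound 2 to compound 3 (1.99 log units; beyond the scatter), with the rest of the core unchanged. The entering group has 8 heavy atoms against 7 and includes a chlorine, while both groups keep one six-membered aromatic ring of carbon only and have no hydrogen-bond donors or acceptors. No measurement shown here accounts for the size of this step.

The compounds shown leave open whether the step belongs to the chlorine or to the benzyl form of the group, which unsubstituted benzyl or 2-chlorophenyl on that nitrogen would separate. They also leave open how an amine or a carboxylic acid on the aromatic ring of the benzyl group would read.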